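Replacing a Fluoro Group with a Bulky Amino Substituent

A few compounds are considered here, and "the series" means these few. Any claim that something is new, unique, unknown or untested is made for them only; others in the source may bear on it.

Compound 1, `O=S(=O)(/C=C/c1c(F)c(F)c(F)c(F)c1F)Nc1c(F)c(F)c(F)c(F)c1F`: 35000 nM
Compound 2, `COc1cc(OC)c(/C=C/S(=O)(=O)Nc2ccc(OC)c(F)c2)c(OC)c1`: 75 nM
Compound 3, `COc1ccc(NS(=O)(=O)/C=C/c2cc(OC)c(OC)c(OC)c2)cc1N`: 15000 nM

All three were tested in a functional assay on K562 cells (Homo sapiens) for cytotoxicity, read by trypan blue exclusion, with a stated time of 96 h; on this read-out higher numbers stand for weaker inhibition and lower numbers for stronger inhibition. Compound 2 has the lowest number of the three; compound 3 shows a higher number, beyond the scatter, and compound 1 a higher one still. Compound 4, `COc1cc(OC)c(/C=C/S(=O)(=O)Nc2ccc(OC)c(NC(C(=O)O)c3ccc(Cl)cc3)c2)c(OC)c1`, is not yet measured. It differs from compound 2 in one place: (carboxy(4-chlorophenyl)methyl)amino in place of fluoro on an aromatic carbon. Compound 3 also carries an amino group and gives a much higher number than compound 2, so a step toward weaker inhibition is expected here as well. For compound 4 the expected step is a 67-fold higher number from compound 2 to compound 4 (1.82 log units; beyond the scatter). Compound 4 is therefore estimated at 5000 nM, within a range from 500 nM to 40000 nM.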

Compound 4, half-maximal inhibitory concentration: 15 nM
For compound 4 the middle estimate is 330-fold (2.52 log units) above the measured one; measured number outside the range, below it.
By their numbers in this assay, from the lowest: compound 4; then compound 2; then compound 3; then compound 1.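

In this assay, the place ortho to a methoxy group holds far more than a fluoro: the (carboxy(4-chlorophenyl)methyl)amino group, with its added aromatic ring, gives a 5.0-fold lower number from compound 2 to compound 4 (0.70 log units; beyond the scatter) rather than a step toward weaker inhibition. In this one pair, then, a much larger group is accepted at this position. Nothing measured here accounts for the stronger inhibition.

Which part of the new group matters remains open. A methyl ester in place of the carboxylic acid, or a phenyl ring without the chlorine, would help separate the contributions.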